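Exchanging Acetyl for Oxazolyl on the Anilide Ring

This account rests on a few compounds, and the source may have more. Where it says the series, first, only, none or still open, it means among the compounds named here.

Compound 1 `O=C(Nc1cccc([N+](=O)[O-])c1)C1CCCN(C(=O)c2cc(C(F)(F)F)cc(C(F)(F)F)c2)C1` gives 9% in an ADME assay on PC-3 cells (Homo sapiens) for cytotoxicity, read by WST assay, tested at 100 uM; on this read-out higher numbers stand for more inhibition at the one concentration tested (going by the name of the read-out) and lower numbers for less inhibition.
Compound 2 `O=C(Nc1cccc(OCCc2ccccn2)c1)C1CCCN(C(=O)c2cc(C(F)(F)F)cc(C(F)(F)F)c2)C1` gives 5% in this assay.
Compound 3 `CC(=O)c1cccc(NC(=O)C2CCCN(C(=O)c3cc(C(F)(F)F)cc(C(F)(F)F)c3)C2)c1` gives 0% in this assay.

The three compounds share one core and differ only in the group carried on the aromatic carbon of the anilide ring. None of the three readings differs from another by more than the usual scatter: the step of a number 4 percentage points lower from compound 1 to compound 2 (within the scatter) is within the scatter, as are the two steps that end at compound 3, a number 9 percentage points lower from compound 1 to compound 3 (within the scatter) and a number 5 percentage points lower from compound 2 to compound 3 (within the scatter). Compound 3 thus stands within the scatter of both compound 1 and compound 2, so the numbers shown do not separate it from them.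

Compound 4 `O=C(Nc1cccc(-c2cnco2)c1)C1CCCN(C(=O)c2cc(C(F)(F)F)cc(C(F)(F)F)c2)C1` has not yet been measured in this assay. It differs from compound 3 in one place: 1,3-oxazol-5-yl in place of acetyl on an aromatic carbon. The two steps that bear on this change are the ones leading to the acetyl-bearing compound 3, and both were small and within the scatter, as was the remaining step between compound 1 and compound 2. With three quite different groups at this position all giving low readings, compound 4 is expected to stay at a low level as well, with an estimated step of a number 5 percentage points higher from compound 3 to compound 4 (within the scatter) that lies within the scatter. Compound 4 is estimated at 5%, with an expected range from -5% to 15%.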

Compound 4, a percentage reported as inhibition, at one concentration (the size of the read-out at that concentration, not a potency): 9%
Estimate against measurement, compound 4: 4 percentage points below, within the range that was stated.
By their numbers in this assay, from the lowest: compounds 3, 2, 1 and 4 (each within the scatter of the next).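

Replacing acetyl, which has no ring, with 1,3-oxazol-5-yl places a five-membered aromatic ring with 2 hetero atoms directly on the aromatic carbon, and in this assay this gives a number 9 percentage points higher from compound 3 to compound 4 (within the scatter) as its step. The comparisons with the other two groups read a number 4 percentage points higher from compound 2 to compound 4 (within the scatter) and no change at the digits printed from compound 1 to compound 4 (within the scatter) and likewise leave compound 4 unseparated, so nitro, 2-(pyridin-2-yl)ethoxy, acetyl and 1,3-oxazol-5-yl cannot be told apart at this position by this read-out, even though they differ in size and in whether they carry a ring. No measurement offered here accounts for these readings or links them to any property of the groups.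

Still open, going by these compounds, is whether a different kind of group at this position, such as an amine, a carboxylic acid or a longer chain ending in a hydroxyl group, would give a step beyond the scatter. Because all four compounds share the same core with its two trifluoromethyl groups, they also cannot show how the reading would respond to changes anywhere else in the molecule.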